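The source may hold more compounds than are shown below. What is called first, only, known or untested is meant among the compounds shown, and "the series" means these compounds.

Measured so far in an assay on isolated protein for binding affinity to B1 bradykinin receptor (Homo sapiens); a higher number here means a weaker inhibitor, a lower number a stronger inhibitor:
compound 1, `COC(=O)c1ccccc1N1CCC(C)(CNc2nccc(C)c2NC(=O)CC#N)CC1` — 3500 nM
compound 2, `COC(=O)C1=C(c2ccc(CNc3nccc(C)c3NC(=O)CC#N)cc2)CCC1` — 126 nM

Two compounds carry numbers in this assay, and compound 2 has the lower one, the gap to compound 1 lying beyond the scatter. Among the compounds with values here, no single-point step links the two measured structures, so only the two values themselves can be compared.

Compound 3, `COC(=O)C1CCCN1c1ccc(CNc2nccc(C)c2NC(=O)CC#N)cc1`, has not been measured. It differs from compound 2 in one place: 2-(methoxycarbonyl)pyrrolidin-1-yl in place of 2-(methoxycarbonyl)cyclopent-1-en-1-yl on an aromatic carbon. The ester stays, but the ring that carries it changes from an all-carbon one with a ring double bond to a saturated one with a ring nitrogen bound to the aromatic carbon. Within the data shown here, no measured pair shows the effect of such a change, so the step is expected to be modest and somewhat toward a higher number, with a wide range; the expected step from compound 2 to compound 3 is a 2.4-fold higher number from compound 2 to compound 3 (0.38 log units; beyond the scatter). Compound 3 is expected to give about 300 nM in this assay, between 60 nM and 1500 nM.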

Compound 3, inhibition constant: > 5000 nM
Compound 3: only a limit was reported; the forecaster's own chance of this, stated with the estimate: 5%; at least 16-fold (1.22 log units) between middle value and limit.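

In this assay, placing 2-(methoxycarbonyl)pyrrolidin-1-yl in place of 2-(methoxycarbonyl)cyclopent-1-en-1-yl on this aromatic carbon gives an at least 39-fold higher number from compound 2 to compound 3 (1.59 log units; beyond the scatter). Both groups carry the methoxycarbonyl on a five-membered ring, so these shared features alone do not preserve the binding seen with compound 2 at this position. Compound 3 has only a limit, so the step gives a floor and not a size: the limit of > 5000 nM in this assay, at which 1 of the 3 values shown sits.

From the compounds shown here alone, the ring nitrogen bound to the aromatic carbon and the loss of the ring double bond change together in this pair, and their separate contributions remain open. Also open, going by these compounds, is how a carboxylic acid in place of the methyl ester, or a saturated cyclopentane ring bearing the same ester, would read at this position.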